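This account rests on a few compounds, and the source may have more. Where it says the series, first, only, none or still open, it means among the compounds named here.

In an ADME assay on MT4 cells (Homo sapiens) for cytotoxicity, read by spectrophotometry, with a stated time of 5 days (on this read-out higher numbers stand for lower toxicity in this test and lower numbers for higher toxicity in this test), compound 2 `CCN(CC)CN1C(=O)/C(=N\NC(=S)NO)c2cc(Cl)ccc21` gives 562000 nM. Compound 3 `CN(C)CN1C(=O)/C(=N\NC(=S)NO)c2cc(Cl)ccc21`, with dimethylamino in place of diethylamino, gives 610000 nM, and the two stand level: the data show a 1.1-fold higher number from compound 2 to compound 3 (0.04 log units; within the scatter). Compound 1 `CONC(=S)N/N=C1\C(=O)N(CN2CCN(c3ccc(Cl)cc3)CC2)c2ccc(Cl)cc21`, which differs from both in several places, gives 229000 nM. That is a lower number than compound 2 shows, and the gap lies beyond the scatter, but with several differences at once it cannot be tied to any single change.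

Compound 4 `CCN(CC)CN1C(=O)/C(=N\NC(=S)NO)c2cc(C)ccc21` keeps the diethylamino group of compound 2 and carries methyl in place of chloro on an aromatic carbon. Among the compounds with values here, no measured pair changes this group, so the data offer no direct precedent for the swap. Within the data shown here, the one measured single-place step, a 1.1-fold higher number from compound 2 to compound 3 (0.04 log units; within the scatter), lies elsewhere in the molecule and bears on this change only indirectly, showing that a small change there left the number within the scatter. No step beyond the scatter is therefore expected in this assay, and no direction is favoured. The estimated change is a 1.1-fold lower number from compound 2 to compound 4 (0.03 log units; within the scatter), which is expected to stay within the scatter. For compound 4 the expected value is 520000 nM, with an estimated range from 260000 nM to 1000000 nM.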

Compound 4, half-maximal cytotoxic concentration: 534000 nM
Estimate against measurement, compound 4: 1.0-fold (0.01 log units) below; the measured number falls inside the stated range.
By their numbers in this assay, from the lowest: compound 1; then compounds 4, 2 and 3 (each within the scatter of the next).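

Compounds 1, 2 and 3 all carry chloro on this aromatic carbon, so they could say nothing about what a change at this position does; compound 4 gives the first reading there. In this assay, methyl in place of chloro, one heavy atom for another with no hydrogen-bond donor or acceptor entering or leaving, gives a 1.1-fold lower number from compound 2 to compound 4 (0.02 log units; within the scatter), so with the diethylamino group in place, compound 2 and compound 4 stand level and this swap at this position leaves the number unmoved beyond the scatter. The data offer no explanation of why this exchange is tolerated.

The compounds shown leave open whether this holds only for a group as small as methyl or chloro, or whether a methoxy group, a nitro group or a carboxylic acid on the same carbon would also stand level with compound 2. They also leave open whether methyl in place of chloro reads the same when dimethylamino replaces diethylamino, or when the group on the ring nitrogen is the larger chlorophenyl piperazine of compound 1.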